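Replacing the nitro group of compound 2 with methoxy

The source may hold more compounds than are shown below. What is called first, only, known or untested is meant among the compounds shown, and "the series" means these compounds.

Compound 1 `COc1cc(-n2c(-c3ccc(Br)cc3)cn(C(C)=O)c2=O)cc(OC)c1OC` – 10600 nM
Compound 2 `COc1cc(-n2c(-c3ccc([N+](=O)[O-])cc3)cn(C(C)=O)c2=O)cc(OC)c1OC` – > 50000 nM

Both values come from a functional assay on MCF7 cells (Homo sapiens) for cytotoxicity, read by MTT assay, with a stated time of 48 h (a higher number here means a weaker inhibitor, a lower number a stronger inhibitor), and the two compounds share one core. Compound 1 has a measured number (10600 nM) in this pair. Compound 2 stands only at a limit (> 50000 nM) and has no number of its own.

Compound 3 `COc1ccc(-c2cn(C(C)=O)c(=O)n2-c2cc(OC)c(OC)c(OC)c2)cc1` has not yet been measured and differs from compound 2 in one place (methoxy in place of nitro on an aromatic carbon) with methoxy in place of nitro on an aromatic carbon, para to a large group. Among the compounds with values here, the only measured step that bears on this change is the one that put nitro in place of bromo on an aromatic carbon (an at least 4.7-fold higher number from compound 1 to compound 2 (0.67 log units; beyond the scatter)) and it lies beyond the scatter. Here nitro leaves, although methoxy rather than bromo enters, so the number in this assay is expected to fall back toward that of compound 1 (10600 nM) on the evidence of this single step. The expected change is toward a lower number, of about the same size as that step (an at least 4.1-fold lower number from compound 2 to compound 3 (0.61 log units; beyond the scatter)). Compound 3 is estimated at 12000 nM (expected range 3000 nM to 50000 nM).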

Compound 3, half-maximal inhibitory concentration: > 50000 nM
Compound 3: no number, only a limit; the forecaster's own chance of this, stated with the estimate: 20%; middle value at least 4.1-fold (0.61 log units) from the limit.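

In this assay compound 3 gives > 50000 nM, which is a limit of the assay and not a number. Methoxy in place of bromo on this aromatic carbon, para to a large group, gives an at least 4.7-fold higher number from compound 1 to compound 3 (0.67 log units; beyond the scatter), so the loss seen earlier with nitro is not confined to that one group, and of the three groups shown only bromo leaves a measured number. The step between the nitro and methoxy compounds cannot be read, because both stand at the same limit: the limit of > 50000 nM in this assay, at which 2 of the 3 values shown sit.

On these data alone, whether another halogen such as chloro, an amine, or a longer chain such as ethoxy on this carbon would bring a measured number back in this assay stays open, so it cannot yet be said whether bromo is unusual here or methoxy and nitro are. The three compounds differ only at this one carbon, so they also say nothing about changes elsewhere on the shared core.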